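Amide variation at the carbonyl of compound 2

This account rests on a few compounds, and the source may have more. Where it says the series, first, only, none or still open, it means among the compounds named here.

Three compounds of this series carry a value in an assay on brain with Translocator protein (Rattus norvegicus) as the target; a lower number here means a stronger inhibitor, a higher number a weaker inhibitor. Compound 1 `Cc1nc2ccccc2c(-c2ccccc2)c1C(=O)N(C)c1ccccc1` reaches only the limit of the assay, > 10000 nM, and not a number. Compound 3 `CCOC(=O)c1c(Cl)nc2ccccc2c1-c1ccccc1` gives 3700 nM. Compound 2 `CCN(Cc1ccccc1)Cc1nc2ccccc2c(-c2ccccc2)c1C(=O)N(CC)CC` gives 373 nM, the lowest of the two numbers shown, with compound 3 as its nearest neighbour at a gap beyond the scatter. Among the compounds with values here, no pair among the three differs in one place only, so no single step is known from measured compounds; what is known of compound 1 is its position at the limit (the limit of > 10000 nM in this assay, at which 1 of the 3 values shown sits).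

Compound 4 `CCN(Cc1ccccc1)Cc1nc2ccccc2c(-c2ccccc2)c1C(=O)NCc1ccccc1` is the next member to be measured. It differs from compound 2 in one respect: benzylamino in place of diethylamino on a carbonyl carbon whose other neighbour is aromatic carbon. Within the data shown here, no measured step bears on this change. The expectation is a step from compound 2 to compound 4 of a 4.0-fold higher number from compound 2 to compound 4 (0.60 log units; beyond the scatter), in the direction of a weaker inhibitor, modest but likely beyond the scatter. Compound 4 is therefore expected to give about 1500 nM in this assay, within 300 nM to 6000 nM.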

Compound 4, half-maximal inhibitory concentration: 2900 nM
For compound 4 the middle estimate is 1.9-fold (0.29 log units) below the measured one, within the range that was stated.
By their numbers in this assay, from the lowest: compound 2; then compounds 4 and 3 (each within the scatter of the next). At a limit, above all of these: compound 1.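

In this assay, within the data shown here, the carbonyl carbon is the first place with a measured single change: benzylamino in place of diethylamino gives a 7.8-fold higher number from compound 2 to compound 4 (0.89 log units; beyond the scatter), so the activity at this position depends on the amide group it carries. The entering group differs from the leaving one in several ways at once, with more heavy atoms, a six-membered aromatic ring and a hydrogen-bond donor, and this single step cannot separate these differences. Among these compounds, nothing measured so far gives a cause for the step.

Still open, on these data alone, is which of these differences carries the step: a benzylmethylamino group on the same carbonyl carbon would keep the ring without the amide hydrogen, while a propylamino group would keep the amide hydrogen without the ring. Also open is whether the step would be the same with other substituents on the core, since the only single-place pair shown is the one at this carbonyl carbon.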